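The source may report more compounds than this note shows. Statements on the series, on what has been measured and on what is new or still open speak of the compounds shown alone.

Compounds 1, 2 and 3 share one core and differ only in one group on an amine nitrogen. Compound 1 `Cc1ccc2cc(CN(Cc3ccc(F)cc3)Cc3ccc(C(C)(C)C)cc3)c(=O)[nH]c2c1` carries 4-fluorobenzyl there, compound 2 `Cc1ccc2cc(CN(Cc3ccc(C(C)(C)C)cc3)C3CCCC3)c(=O)[nH]c2c1` cyclopentyl, and compound 3 `CCCCOc1ccc(CN(Cc2ccc(C(C)(C)C)cc2)Cc2cc3cc(C)ccc3[nH]c2=O)cc1` 4-butoxybenzyl. In a toxicity assay on MDCK cells (Canis lupus familiaris) for cytotoxicity, read by crystal violet staining, with a stated time of 48 h (a higher number here means that more compound is tolerated, a lower number that less compound is tolerated), compound 1 reaches only the limit of the assay, > 33000 nM. Compound 2 likewise gives only a limit, > 10000 nM. Compound 3 also stands at a limit and not at a number, > 5000 nM. Among the measured compounds shown here, because every value shown is a limit (the limit of > 10000 nM in this assay, at which 1 of the 3 values shown sits, (the limit of > 33000 nM in this assay, at which 1 of the 3 values shown sits), (the limit of > 5000 nM in this assay, at which 1 of the 3 values shown sits)), the one step between measured compounds, a step that the two limits leave unreadable from compound 1 to compound 2, cannot be read, and no step has a known size.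

Compound 4 `Cc1ccc2[nH]c(=O)c(CN(Cc3ccc(C(C)(C)C)cc3)C(C)c3ccc(F)cc3)cc2c1` differs from compound 3 by 1-(4-fluorophenyl)ethyl in place of 4-butoxybenzyl on an amine nitrogen. Compound 1, which carries 4-fluorobenzyl at the same nitrogen, gave only a limit, > 33000 nM. Compound 4 is therefore expected to remain well tolerated, with an estimated 30000 nM and a range from 8000 nM to 100000 nM. The step expected here is a step that the limit leaves unreadable from compound 3 to compound 4, most likely again reported only as a limit.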

Compound 4, half-maximal cytotoxic concentration: > 33000 nM
Compound 4 ended at the assay's limit (the forecaster's own chance of this, stated with the estimate: 75%); at least 1.1-fold (0.04 log units) between middle value and limit.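

Compound 3 and compound 4 each gave only a limit and not a number, and the step between them cannot be read. In this assay the compounds shown leave open at what concentration any of them begins to harm the cells.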